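Extending the Alkyl Chain of an Acyltransferase Inhibitor

The compounds below may be only part of what the source reports. "The series", "measured", "known", "first", "only" and "open" are said of these compounds alone.

Compound 1 `CC(C)c1cccc(C(C)C)c1OC(=O)NC(=O)OCCCc1ccccc1`: 660 nM
Compound 2 `CCCCCCCCCCOC(=O)NC(=O)Oc1c(C(C)C)cccc1C(C)C`: 74 nM

Both compounds were tested in an assay on microsomes from intestine for inhibition of acyl-CoA:cholesterol acyltransferase (Oryctolagus cuniculus); a higher number here means a weaker inhibitor, a lower number a stronger inhibitor. Going by the values given here, compound 2 stands at the lowest number of the two; the only measured step, an 8.9-fold lower number from compound 1 to compound 2 (0.95 log units; beyond the scatter), separates it from compound 1, and it is also the only step that bears on what comes next.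

Compound 3 `CCCCCCCCCCCCCCCCCCOC(=O)NC(=O)Oc1c(C(C)C)cccc1C(C)C` differs from compound 2 by octyl in place of hydrogen on a saturated chain carbon, ten or more bonds along the chain from an oxygen next to a carbonyl group. The measured step swapped a ring-bearing group for a longer saturated chain at the same end of the shared core and brought a modest gain. Compound 3 carries that chain further still. Among the compounds with values here, no measured pair shows whether more chain keeps lowering the number or whether the gain has already run its course, so the expectation for compound 3 is a small change at most, leaning toward a slightly lower number. Compound 3 is therefore estimated at 50 nM in this assay, with a range from 15 nM to 200 nM. That corresponds to an expected step of a 1.5-fold lower number from compound 2 to compound 3 (0.17 log units; within the scatter).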

Compound 3, half-maximal inhibitory concentration: 1000 nM
Compound 3: middle estimate off by 20-fold (1.30 log units), on the low side; measured number outside the range, above it.
By their numbers in this assay, from the lowest: compound 2; then compounds 1 and 3 (each within the scatter of the next).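

In this assay, the added octyl on a saturated chain carbon gives a 14-fold higher number from compound 2 to compound 3 (1.13 log units; beyond the scatter). The earlier step, an 8.9-fold lower number from compound 1 to compound 2 (0.95 log units; beyond the scatter), could suggest that more saturated chain at this end of the shared core would keep lowering the number, but this result shows that the gain does not simply continue and that a longer chain can make a much weaker inhibitor. Of the chains shown, the one in compound 2 therefore gives the lowest number, and no information at hand explains why the number rises with the added octyl.

On these data alone, with only these two chain lengths to compare, the point at which the number turns upward remains open, and butyl in place of the same hydrogen could land on either side of compound 2. As far as these compounds go, it is also open whether a long chain ending in a carboxylic acid or an amine would behave like the plain saturated chain of compound 3.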